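The compounds below may be only part of what the source reports. "The series", "measured", "known", "first", "only" and "open" are said of these compounds alone.

Measured in a functional assay on HCT-116 cells (Homo sapiens) for inhibition, read by CCK-8 assay, with a stated time of 72 h; on this read-out higher numbers stand for weaker inhibition and lower numbers for stronger inhibition:
- compound 1 `Nc1ccccc1NC(=O)c1ccc(CNC(=O)c2n[nH]cc2NC(=O)c2c(F)cccc2Cl)cc1`: 700 nM
- compound 2 `Nc1ccccc1NC(=O)c1ccc(CNC(=O)c2n[nH]cc2NC(=O)c2ccccc2)cc1`: 1660 nM
- compound 3 `Nc1ccccc1NC(=O)c1ccc(CNC(=O)c2n[nH]cc2NC(=O)c2c(Cl)cccc2Cl)cc1`: 710 nM

Compound 3, at 710 nM, is level with compound 1: the record shows a 1.0-fold higher number from compound 1 to compound 3 (0.01 log units; within the scatter). Against the unsubstituted phenyl of compound 2, the record shows a 2.3-fold lower number from compound 2 to compound 3 (0.37 log units; beyond the scatter). The next structure is compound 4 `Nc1ccccc1NC(=O)c1ccc(CNC(=O)c2n[nH]cc2NC(=O)c2ccccc2F)cc1`, and the change is 2-fluorophenyl in place of 2,6-dichlorophenyl on a carbonyl carbon.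

For the measured compounds named here, three measured steps bear on this change, all at the same place on a carbonyl carbon. Removing the halogens altogether gave a 2.4-fold higher number from compound 1 to compound 2 (0.38 log units; beyond the scatter), a modest step beyond the scatter. Going by the values given here, exchanging one halogen for another gave a 1.0-fold higher number from compound 1 to compound 3 (0.01 log units; within the scatter), which is no measurable step. Among the compounds with values here, no 2-fluorophenyl compound has been measured, so the effect of this group alone remains open. The 2-fluorophenyl group still carries a halogen, so compound 4 is expected to fall between the halogenated pair and compound 2, with a small rise in the number in this assay. The estimated step is a 1.5-fold higher number from compound 3 to compound 4 (0.19 log units; within the scatter). For compound 4 the expected value is 1100 nM, with an estimated range of 600 nM to 2000 nM.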

Compound 4, half-maximal inhibitory concentration: 4800 nM
The estimate for compound 4 lay 4.4-fold (0.64 log units) below the measured number; measured number outside the range, above it.
By their numbers in this assay, from the lowest: compounds 1 and 3 (each within the scatter of the next); then compound 2; then compound 4.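

In this assay, a halogen at this position does not lower the number on its own: with fluoro in place of hydrogen on an aromatic carbon, the record gives a 2.9-fold higher number from compound 2 to compound 4 (0.46 log units; beyond the scatter), so this change moves the number the opposite way from the 2,6-dichlorophenyl group. The 2-fluorophenyl group also stands well apart from both dihalogenated groups, with a 6.9-fold higher number from compound 1 to compound 4 (0.84 log units; beyond the scatter) for hydrogen in place of chloro and a 6.8-fold higher number from compound 3 to compound 4 (0.83 log units; beyond the scatter) for 2-fluorophenyl in place of 2,6-dichlorophenyl, so the number does not follow halogen count across these four compounds, and compound 4 is the one that goes against a steady order from none to one to two halogens. Nothing in the data accounts for this order.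

Still open, as far as these compounds go, is whether the rise belongs to fluoro itself or to the single substituent, which a lone chloro, methyl or methoxy on the same aromatic carbon would help separate. Also open, from the compounds shown here alone, is whether a methyl or methoxy pair on the ring would give numbers level with compound 1 and compound 3, or whether that level needs halogens.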